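Swapping a pyridyl ketone for a dimethoxyphenyl ketone

The compounds below may be only part of what the source reports. "The series", "measured", "known", "first", "only" and "open" are said of these compounds alone.

Compound 1 `COc1cc(C(=O)/C=C/c2cn(-c3ccccc3)nc2-c2ccsc2)cc(OC)c1OC` gives 4900 nM in a functional assay on MCF7 cells (Homo sapiens) for inhibition, read by sulforhodamine B assay, with a stated time of 72 h; on this read-out lower numbers stand for stronger inhibition and higher numbers for weaker inhibition.
Compound 2 `COc1cc(OC)c(C(=O)/C=C/c2cn(-c3ccccc3)nc2-c2ccsc2)c(OC)c1` gives 2700 nM in this assay.
Compound 3 `O=C(/C=C/c1cn(-c2ccccc2)nc1-c1cccnc1)c1ccccn1` gives 4200 nM in this assay.

Of these three numbers, compound 3 sits second highest, closest to compound 1 and furthest from compound 2, yet both gaps are within the usual scatter, so no ordering among the three can be claimed. Compound 4 `COc1ccc(C(=O)/C=C/c2cn(-c3ccccc3)nc2-c2cccnc2)cc1OC` has not yet been measured in this assay. It differs from compound 3 in one place: 3,4-dimethoxyphenyl in place of pyridin-2-yl on a carbonyl carbon. Among the measured compounds shown here, no measured pair shows this exact change, so the expectation rests only on the fact that all three measured compounds, despite their varied ketone-side rings, land close together. The step from compound 3 to compound 4 is therefore expected to be small, a 1.2-fold lower number from compound 3 to compound 4 (0.08 log units; within the scatter), not beyond the scatter. Compound 4 is estimated to give 3500 nM, with a likely range from 1200 nM to 10000 nM.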

Compound 4, half-maximal inhibitory concentration: 1700 nM
The estimate for compound 4 lay 2.1-fold (0.31 log units) above the measured number; measured number inside the range.
By their numbers in this assay, from the lowest: compounds 4, 2, 3 and 1 (each within the scatter of the next, the first and the last beyond it).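

In this assay, among the compounds shown here, the ring on the carbonyl carbon turns out to matter: 3,4-dimethoxyphenyl in place of pyridin-2-yl gives a 2.5-fold lower number from compound 3 to compound 4 (0.39 log units; beyond the scatter), a modest step but the first single-place change here that can be read. Nothing available explains this difference.

Going by these compounds, it remains open whether the step comes from losing the ring nitrogen or from gaining the two methoxy groups. Equally open, on these data alone, is how a plain phenyl ring, or one carrying an amine or a carboxylic acid, would behave at this place.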